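Fluoro for methyl in an antiproliferative series

A few compounds are considered here, and "the series" means these few. Any claim that something is new, unique, unknown or untested is made for them only; others in the source may bear on it.

compound 1 `Cc1ccc(C(=O)NC(N)=O)cc1NC(=O)C(C)Br` — 3360 nM
compound 2 `CC(Br)C(=O)Nc1cc(C(=O)NC(N)=O)ccc1F` — 3130 nM
compound 3 `Cc1ccc(NC(=O)CBr)cc1C(=O)NC(N)=O` — 4760 nM

These three were measured in a functional assay on CCRF-CEM cells (Homo sapiens) for antiproliferative activity, read by trypan blue exclusion, with a stated time of 72 h; on this read-out lower numbers stand for stronger inhibition and higher numbers for weaker inhibition. Compound 2 differs from compound 1 by fluoro in place of methyl on an aromatic carbon, a step of a 1.1-fold lower number from compound 1 to compound 2 (0.03 log units; within the scatter). Compound 4 `NC(=O)NC(=O)c1cc(NC(=O)CBr)ccc1F` is not yet measured; it differs from compound 3 by fluoro in place of methyl on an aromatic carbon. The difference between the core of compound 1 and the core of compound 3 is not broken down here. The two changes are the same kind of change but not the same: in compound 1 the place is ortho to a ((1-bromoethyl)carbonyl)amino group and para to a carbamoylcarbamoyl group, while in compound 3 it is ortho to a carbamoylcarbamoyl group and para to a ((bromomethyl)carbonyl)amino group. For compound 4 a step of a 1.1-fold lower number from compound 3 to compound 4 (0.03 log units; within the scatter) is expected, resting on a 1.1-fold lower number from compound 1 to compound 2 (0.03 log units; within the scatter). Compound 4 is estimated at 4400 nM in this assay, between 2000 nM and 9500 nM.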

Compound 4, half-maximal inhibitory concentration: < 10 nM
Compound 4: only a limit was reported (the forecaster's own chance of this, stated with the estimate: 5%); at least 440-fold (2.64 log units) between middle value and limit.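

In this assay, fluoro in place of methyl on an aromatic carbon gives an at least 470-fold lower number from compound 3 to compound 4 (2.67 log units; beyond the scatter), so the result on one core did not predict the result on the other: the same change on two cores in this assay, a 1.1-fold lower number (0.03 log units; within the scatter) from compound 1 to compound 2 and an at least 470-fold lower number (2.67 log units; beyond the scatter) from compound 3 to compound 4, at least 440-fold (2.64 log units) apart, beyond the scatter of two such steps

Compound 4 carries a limit of the assay rather than a number, so the full size of its step remains unknown: the limit of < 10 nM in this assay, at which 1 of the 4 values shown sits.

These two pairs do not show which difference between the cores separates the two steps, and they give no rule for any further core.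

Open, going by these compounds, is whether the large step is specific to fluoro or would also appear with chloro or methoxy at the same place on the core of compound 3. Also open, on these data alone, is how a ((1-bromoethyl)carbonyl)amino group would read in place of the ((bromomethyl)carbonyl)amino group of compound 4.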